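A few compounds are considered here, and "the series" means these few. Any claim that something is new, unique, unknown or untested is made for them only; others in the source may bear on it.

Compound 1 `CCCc1nc(-c2ccccc2)c(CNCCCN2CCN(c3cccc(C)c3C)CC2)o1` carries a 2,3-dimethylphenyl group on the amine nitrogen of its saturated ring. In an assay on HEK293 cells for inhibition of Voltage-dependent T-type calcium channel subunit alpha-1G (Homo sapiens), read by patch clamp (a lower number here means a stronger inhibitor, a higher number a weaker inhibitor), compound 1 gives 1780 nM. Its companion compound 2 `CCCc1nc(-c2ccccc2)c(CNCCN2CCN(c3cccc(C)c3C)CC2)o1` gives in this assay 1710 nM, and the two numbers lie within the scatter of each other, so compound 1 stands level with compound 2 rather than apart from it. Compound 3 `CCCc1nc(-c2ccccc2)c(CNCCCN2CCN(c3ccccc3Cl)CC2)o1` has not yet been measured. It differs from compound 1 in one place: 2-chlorophenyl in place of 2,3-dimethylphenyl on an amine nitrogen in a ring. Within the data shown here, no measured pair shows what this exchange does, so the expectation rests on the two measured compounds alone, which sit close together. For compound 3 in this assay a step expected to be no larger than the scatter, with a small loss allowed for, seems most likely. The step of a 1.2-fold higher number from compound 1 to compound 3 (0.09 log units; within the scatter) is the expected one. Compound 3 is thus estimated at 2200 nM, within 800 nM to 6000 nM.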

Compound 3, half-maximal inhibitory concentration: 2800 nM
Estimate against measurement, compound 3: 1.3-fold (0.10 log units) below; the range from low to high includes it.
By their numbers in this assay, from the lowest: compounds 2, 1 and 3 (each within the scatter of the next).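

Both earlier compounds carry 2,3-dimethylphenyl, so they could say nothing about this place on the amine nitrogen in the ring. In this assay, putting 2-chlorophenyl there gives a 1.6-fold higher number from compound 1 to compound 3 (0.20 log units; within the scatter) and so leaves the read-out within the scatter, which means this exchange of one substituted phenyl group for another has no clear effect on T-type channel inhibition in this series. No measurement shown explains this outcome or separates what the chlorine and the methyl groups each contribute.

From the compounds shown here alone, whether the place stays as undemanding for a group of a different kind, such as a phenyl ring carrying a carboxylic acid or an amine, remains open. Also open, going by these compounds, is whether the same exchange would behave alike on compound 2 with its different chain.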